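A substituent swap on a ring nitrogen, awaiting its number

The source may hold more compounds than are shown below. What is called first, only, known or untested is meant among the compounds shown, and "the series" means these compounds.

Of the compounds shown here, three have been tested in a functional assay on K562 cells (Homo sapiens) for cytotoxicity, read by trypan blue exclusion, with a stated time of 96 h; a higher number here means a weaker inhibitor, a lower number a stronger inhibitor. Compound 1 `COc1ccc(CS(=O)(=O)/C=C/c2c(OC)cccc2OC)cc1N` gives 50 nM in this assay. Compound 2 `COc1cc(OC)c(/C=C/S(=O)(=O)Cc2ccc(OC)cc2[N+](=O)[O-])c(OC)c1` gives 20000 nM in this assay. Compound 3 `COC(=O)C(F)(F)Nc1cc(CS(=O)(=O)/C=C/c2c(OC)cc(OC)cc2OC)ccc1OC` gives 250 nM in this assay. Compound 3 therefore stands second highest of the three numbers: its nearest neighbour is compound 1, whose number is lower by a margin beyond the scatter, and its furthest is compound 2, whose number is higher by a margin far beyond the scatter.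

Compound 4 `COc1ccc(C(Nc2cc(CS(=O)(=O)/C=C/c3c(OC)cc(OC)cc3OC)ccc2OC)C(=O)O)cc1` has not yet been measured. It differs from compound 3 in a single place: carboxy(4-methoxyphenyl)methyl in place of difluoro(methoxycarbonyl)methyl on a nitrogen on an aromatic ring. The group that leaves carries no hydrogen-bond donor, whereas the group that enters carries one and brings a six-membered aromatic ring of carbon only. Within the data shown here, no pair among the measured compounds differs in exactly this place, so the three measured numbers give no direct guide to the size or direction of this exchange. The step of a 1.6-fold higher number from compound 3 to compound 4 (0.20 log units; within the scatter) is expected to be small, a mild weakening that need not reach beyond the scatter. Compound 4 is accordingly estimated at 400 nM in this assay, with a range from 80 nM to 2500 nM.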

Compound 4, half-maximal inhibitory concentration: 15 nM
Estimate against measurement, compound 4: 27-fold (1.43 log units) above, outside the stated range (below it).
By their numbers in this assay, from the lowest: compound 4; then compound 1; then compound 3; then compound 2.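

The nitrogen on the aromatic ring proves to be a place where the attached group matters strongly: carboxy(4-methoxyphenyl)methyl in place of difluoro(methoxycarbonyl)methyl gives a 17-fold lower number from compound 3 to compound 4 (1.22 log units; beyond the scatter) in this assay, a large step. Among these compounds, the entering group is the bigger of the two and brings a six-membered aromatic ring of carbon only and a hydrogen-bond donor, yet it goes with a stronger result, so this position accepts far more bulk than the earlier compounds could show, since no measured pair before this one differed in a single place. No measurement at hand accounts for the drop in the number, so the step stands as an observation only.

The exchange alters the aromatic ring, the fluorines and the ester-to-carboxylic-acid change all at once, so the compounds shown cannot tell which of these parts carries the effect. From the compounds shown here alone, how a plain benzyl group or a carboxymethyl group on the same nitrogen would read in this assay stays open, as does whether this exchange would act the same way on the core of compound 1.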